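Compound 2 to compound 3: one added methyl

The source may report more compounds than this note shows. Statements on the series, on what has been measured and on what is new or still open speak of the compounds shown alone.

Of the compounds shown here, two have been read in an ADME assay on WI-38 cells (Homo sapiens) for cytotoxicity, read by MTT assay, with a stated time of 48 h; a higher number here means a weaker inhibitor, a lower number a stronger inhibitor. Compound 1 (`Cc1cnc(C(=O)Oc2ccc(C(N)=S)cc2)c[n+]1[O-]`) gives > 800000 nM, a limit of the assay and not a number. Compound 2 (`O=C(NCCOC(=S)Nc1ccccc1)c1cccnc1`) gives > 800000 nM, again only a limit. Within the data shown here, the series so far stands on (the limit of > 800000 nM in this assay, at which 2 of the 2 values shown sit), so compound 2 has no numeric value to build on.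

Compound 3 (`Cc1ccc(NC(=S)OCCNC(=O)c2cccnc2)cc1`) carries methyl in place of hydrogen on an aromatic carbon of compound 2, para to a large group: methyl in place of hydrogen on an aromatic carbon. Among the measured compounds shown here, no measured step sizes this change, so no shift in either direction beyond the scatter is expected. The expected change, a number no higher from compound 2 to compound 3 (the limit leaves the size open), is an estimate only. Compound 3 is expected to read about 800000 nM, with an estimated range of 300000 nM to 1500000 nM, and a report as a limit alone is likely.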

Compound 3, half-maximal inhibitory concentration: > 800000 nM
Compound 3: no number, only a limit; the forecaster's own chance of this, stated with the estimate: 75%; the middle value lies on the limit itself.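

In this assay no step can be read between compound 2 and compound 3, because each stands only as a limit of the assay and not as a number: the limit of > 800000 nM in this assay, at which 3 of the 3 values shown sit.

The compounds shown leave open whether methyl in place of hydrogen on an aromatic carbon changes the read-out at all.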